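A few compounds are considered here, and "the series" means these few. Any claim that something is new, unique, unknown or untested is made for them only; others in the source may bear on it.

Compound 1, `CN1CCN(c2nc(-c3cccc(Cl)c3)nc3[nH]cnc23)CC1`: > 80%
Compound 2, `CN1CCN(c2nc(-c3cccc(O)c3)nc3[nH]cnc23)CC1`: > 80%

Both values come from an assay on cells for displacement of a labelled ligand from adenosine receptor A3 (Homo sapiens), read by scintillation counting and radioligand binding, with a stated time of 180 min, tested at 10 uM; a lower number here means less inhibition, a higher number more inhibition at the concentration tested (going by the name of the read-out). For compound 1 the value > 80% is a limit of the assay, not a measured number. For compound 2 the value > 80% is likewise a limit. For the measured compounds named here, because of the limit of > 80% in this assay, at which 2 of the 2 values shown sit, the single measured step, a step that the two limits leave unreadable from compound 1 to compound 2, cannot be read in size; the two compounds may differ or not. As far as these compounds go, compound 1 thus stands at the limit, and how far beyond it is unknown.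

Compound 3, `CN1CCN(c2nc(-c3cccc(Cl)c3)nc3c2ncn3C)CC1`, has not yet been measured. It differs from compound 1 by methyl in place of hydrogen on an aromatic nitrogen. Going by the values given here, no measured step touches this kind of change; the one step that was measured concerns a different part of the molecule and is itself unreadable. The data give no ground for a directed expectation. The estimate for compound 3 in this assay is 70%, with a range from 30% to 95%. The step this estimate implies, a number at least 10 percentage points lower from compound 1 to compound 3 (that floor lies within the scatter), is expected only loosely, with a real chance that the assay again returns only a limit.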

Compound 3, a percentage reported as inhibition, at one concentration (the size of the read-out at that concentration, not a potency): 38.3%
For compound 3 the middle estimate is 31.7 percentage points above the measured one, within the range that was stated.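

For the compounds shown here, this is the first step that can be read in size; the step from chloro to hydroxy on the aromatic carbon cannot. In this assay, methyl in place of hydrogen on an aromatic nitrogen gives a number at least 41.7 percentage points lower from compound 1 to compound 3 (beyond the scatter), so this position is sensitive to a change of just one heavy atom, at least with the chloro group in place. The true drop may be larger, and the printed size is only a floor, because compound 1 stands at a limit and not at a measured number: the limit of > 80% in this assay, at which 2 of the 3 values shown sit.

As far as these compounds go, only hydrogen and methyl appear on this nitrogen, so it remains open whether an ethyl group, a longer chain or a chain ending in an amine or a carboxylic acid would lower the inhibition further, restore it or leave it unchanged. From the compounds shown here alone, it is also open whether the same methyl would have a similar effect alongside the hydroxy group of compound 2, and, as each value is a reading at one concentration, how far the compounds differ in potency.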